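Amide aryl truncation on the shared core

The compounds below may be only part of what the source reports. "The series", "measured", "known", "first", "only" and "open" are said of these compounds alone.

Measured compounds:
compound 1 `COc1cc(-c2nn(-c3cccc(NC(=O)Nc4cccc(C(F)(F)F)c4)c3)cc2-c2ccncc2)ccc1Cl` — 372 nM
compound 2 `COc1cc(-c2nn(-c3cccc(NC(=O)c4ccc(Cl)c(C(F)(F)F)c4)c3)cc2-c2ccncc2)ccc1Cl` — 1290 nM

In a functional assay on PC-3 cells (Homo sapiens) for inhibition, read by sulforhodamine B assay, with a stated time of 48 h (a lower number here means a stronger inhibitor of growth, a higher number a weaker inhibitor of growth), compound 1 gives 372 nM and compound 2 gives 1290 nM. Within the data shown here, compound 2 thus stands at the higher of the two numbers, the weaker growth inhibitor of the pair; the one measured step, a 3.5-fold higher number from compound 1 to compound 2 (0.54 log units; beyond the scatter), swaps the urea-type (3-(trifluoromethyl)phenyl)amino for a directly attached 4-chloro-3-(trifluoromethyl)phenyl on the carbonyl carbon.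

Compound 3 `COc1cc(-c2nn(-c3cccc(NC(=O)c4ccccc4)c3)cc2-c2ccncc2)ccc1Cl` is the next point: phenyl in place of 4-chloro-3-(trifluoromethyl)phenyl on a carbonyl carbon. Among the measured compounds shown here, no measured step changes the substituents of the aryl on the carbonyl carbon while keeping the amide; the single step known alters the linkage instead, so it bears on this change only indirectly, and both measured compounds carry a trifluoromethyl on that ring. Compound 3 is therefore expected to give 2200 nM in this assay, within 700 nM to 7000 nM, an estimated step of a 1.7-fold higher number from compound 2 to compound 3 (0.23 log units; within the scatter).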

Compound 3, concentration for 50% growth inhibition: 426 nM
For compound 3 the middle estimate is 5.2-fold (0.71 log units) above the measured one; measured number outside the range, below it.
By their numbers in this assay, from the lowest: compounds 1 and 3 (each within the scatter of the next); then compound 2.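

In this assay, the plain phenyl on the carbonyl carbon gives a 3.0-fold lower number from compound 2 to compound 3 (0.48 log units; beyond the scatter), so within the amide the growth inhibition does not depend on the chloro and trifluoromethyl substituents of compound 2, and the ring carrying them is the poorer of the two. The step of a 1.1-fold higher number from compound 1 to compound 3 (0.06 log units; within the scatter) shows that the amide bearing plain phenyl cannot be told apart from the urea-type group, so the amide linkage alone does not bring the loss seen with compound 2. No supporting measurement accounts for either step.

Among these compounds, whether the chloro or the trifluoromethyl alone would reproduce the loss stays open, since the amide ring is seen only with both or with neither. Also open, on these data alone, is how the plain phenyl responds to a small substituent such as an amine or a carboxylic acid.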